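Swapping Methyl for Nitro on the Benzyl Ring

This account rests on a few compounds, and the source may have more. Where it says the series, first, only, none or still open, it means among the compounds named here.

Of the compounds shown here, three sharing one core have been tested in a functional assay on PC-3 cells (Homo sapiens) for cytotoxicity, read by sulforhodamine B assay; on this read-out lower numbers stand for stronger inhibition of growth and higher numbers for weaker inhibition of growth. Compound 1 `COc1cccc(OC)c1OCCNCCOc1ccccc1OCc1ccc(Cl)cc1` gives 2400 nM. Compound 2 `COc1cccc(OC)c1OCCNCCOc1ccccc1OCc1cccc(C)c1` gives 12000 nM, and compound 3 `COc1cccc(OC)c1OCCNCCOc1ccccc1OCc1ccc(C)cc1` gives 7800 nM. Among these three numbers compound 3 stands second highest: its nearest neighbour is compound 2, and the two lie within the scatter of each other, while compound 1 sits further off with a lower number, a gap that is beyond the scatter.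

Compound 4 `COc1cccc(OC)c1OCCNCCOc1ccccc1OCc1ccc([N+](=O)[O-])cc1` has not yet been measured in this assay. It differs from compound 3 in one place: nitro in place of methyl on an aromatic carbon. The closest measured step is the one touching the same aromatic carbon, a 3.3-fold higher number from compound 1 to compound 3 (0.51 log units; beyond the scatter), a modest change in which the chloro gave the lower number. Within the data shown here, no measured step involves a nitro group, so the outlook for compound 4 rests only on the observation that the methyl of compound 3 gave a higher number than another group at that carbon. A modest move toward a lower number, or none beyond the scatter, is therefore expected. For compound 4 the estimate is 4500 nM, with a range from 1500 nM to 13000 nM. This expected step, a 1.7-fold lower number from compound 3 to compound 4 (0.24 log units; within the scatter), stays close to the measured neighbourhood.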

Compound 4, concentration for 50% growth inhibition: 12000 nM
For compound 4 the middle estimate is 2.7-fold (0.43 log units) below the measured one, and the stated range covers the measured number.
By their numbers in this assay, from the lowest: compound 1; then compounds 3, 2 and 4 (each within the scatter of the next).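

In this assay, nitro and methyl on this aromatic carbon cannot be told apart: the step is a 1.5-fold higher number from compound 3 to compound 4 (0.19 log units; within the scatter) even though the nitro carries hydrogen-bond acceptors and the methyl carries none. The 4-nitrophenyl and the 3-methylphenyl are just as close, with no change at the digits printed from compound 2 to compound 4 (within the scatter) as the step, while chloro and nitro do separate, with a 5.0-fold higher number from compound 1 to compound 4 (0.70 log units; beyond the scatter) as the step, so of the groups at this part of the molecule only the 4-chlorophenyl of compound 1 stands apart from the rest, with the lowest number of the four. Nothing is available here to explain why chloro differs from methyl and nitro.

Whether that lower number belongs to chloro alone stays open, as compound 1 is the only compound shown with a halogen, and a bromo, a fluoro, an amine or a carboxylic acid on the same aromatic carbon would help to settle it. Equally open, as far as these compounds go, is whether the same picture would hold with a change elsewhere on the shared core, such as a longer chain.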